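Dichlorophenyl Rearrangement in an Arylpropanamide Series

The source may hold more compounds than are shown below. What is called first, only, known or untested is meant among the compounds shown, and "the series" means these compounds.

Compound 1 `CC(C)Cc1ccc(C(C)C(=O)NCc2ccc(F)cc2)cc1` gives 27000 nM in an assay on brain for inhibition of Fatty-acid amide hydrolase 1 (Rattus norvegicus), read by scintillation counting, with a stated time of 10 min; a lower number here means a stronger inhibitor, a higher number a weaker inhibitor.
Compound 2 `CC(C)Cc1ccc(C(C)C(=O)NCc2ccc(Cl)c(Cl)c2)cc1` gives 36000 nM in this assay.

Compound 2 and compound 1 sit within the usual scatter of each other, as the step of a 1.3-fold higher number from compound 1 to compound 2 (0.12 log units; within the scatter) shows. Compound 3 `CC(C)Cc1ccc(C(C)C(=O)NCc2cc(Cl)ccc2Cl)cc1` differs from compound 2 in one place: 2,5-dichlorophenyl in place of 3,4-dichlorophenyl on a saturated chain carbon bound to an amide-type nitrogen. For the measured compounds named here, the only step that bears on this change is a 1.3-fold higher number from compound 1 to compound 2 (0.12 log units; within the scatter), a swap of one substituted phenyl for another on the same carbon, and it stayed within the scatter. A step no larger than the scatter is therefore expected in this assay, in neither direction. Compound 3 is estimated at 32000 nM, between 10000 nM and 100000 nM, which means an expected step of a 1.1-fold lower number from compound 2 to compound 3 (0.05 log units; within the scatter).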

Compound 3, half-maximal inhibitory concentration: 4400 nM
For compound 3 the middle estimate is 7.3-fold (0.86 log units) above the measured one; measured number below the stated range.
By their numbers in this assay, from the lowest: compound 3; then compounds 1 and 2 (each within the scatter of the next).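

Rearranging the two chlorines, with the same atoms joined differently, gives an 8.2-fold lower number from compound 2 to compound 3 (0.91 log units; beyond the scatter) in this assay, so the choice of dichlorophenyl pattern on a saturated chain carbon bound to an amide-type nitrogen does matter. The change from 4-fluorophenyl to 2,5-dichlorophenyl gives a 6.1-fold lower number from compound 1 to compound 3 (0.79 log units; beyond the scatter), so the earlier swap, which stayed within the scatter, did not hold for every substituted phenyl. Nothing available explains this difference. Going by these compounds, whether a single chlorine, or a methoxy group or an amine on the same phenyl, would give a similar number remains open.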